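The source may report more compounds than this note shows. Statements on the series, on what has been measured and on what is new or still open speak of the compounds shown alone.

Of the compounds shown here, three have been tested so far in an ADME assay on MIA PaCa-2 cells (Homo sapiens) for cytotoxicity, read by MTT assay, with a stated time of 72 h; on this read-out lower numbers stand for stronger inhibition and higher numbers for weaker inhibition: compound 1 `COc1ccc(C2=C(c3cc(OC)c(OC)c(OC)c3)C(=O)C(OC(C)=O)C2)cc1OC(C)C`, compound 2 `COc1ccc(C2=C(c3cc(OC)c(OC)c(OC)c3)C(=O)CC2O[SiH2]C(C)(C)C)cc1` and compound 3 `C=CCOc1cc(C2=C(c3cc(OC)c(OC)c(OC)c3)C(=O)C(O)C2)ccc1OC`. Compound 1 gives > 100 ug/mL, which is a limit and not a number. Compound 2 gives > 100 ug/mL, which is also a limit. Compound 3 gives > 100 ug/mL, again a limit. Compound 2 therefore has no rank of its own among these compounds, and the whole picture so far is the limit of > 100 ug/mL in this assay, at which 3 of the 3 values shown sit.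

The next compound is compound 4 `COc1ccc(OC)c(C2=C(c3cc(OC)c(OC)c(OC)c3)C(=O)CC2O[SiH2]C(C)(C)C)c1`, which shares its core with compound 2. The structural difference is 2,5-dimethoxyphenyl in place of 4-methoxyphenyl on a double-bonded ring carbon. Put simply, 2,5-dimethoxyphenyl stands in place of 4-methoxyphenyl on a double-bonded ring carbon.

For the measured compounds named here, no measured pair shows the size of such a change, and no tested compound yet offers a number to compare against. The expectation of no step beyond the usual scatter in this assay, in either direction, rests on compound 2 with its limit of > 100 ug/mL. The expected change is a number no higher from compound 2 to compound 4 (the limit leaves the size open). Compound 4 is estimated at 100 ug/mL, with an expected range from 40 ug/mL to 250 ug/mL.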

Compound 4, half-maximal inhibitory concentration: > 100 ug/mL
Compound 4: only a limit was reported; the forecaster's own chance of this, stated with the estimate: 80%; the middle value sits exactly at the limit.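

Compound 2 and compound 4 each give only a limit in this assay, not a number, so the step from 4-methoxyphenyl to 2,5-dimethoxyphenyl cannot be read. The compounds shown leave open whether this change, or any other on the shared core, alters the read-out, as every value stays at one limit: the limit of > 100 ug/mL in this assay, at which 4 of the 4 values shown sit.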